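The compounds below may be only part of what the source reports. "The series", "measured", "known", "first", "only" and "open" are said of these compounds alone.

Compound 1 `CN1CCN(C(=O)CCCOc2cc(C(=O)N3CCCCc4sccc43)ccc2NC(=O)c2ccccc2-c2ccccc2)CC1` gives 1 nM in an assay on adrenal medulla for inhibition of Vasopressin V2 receptor (Rattus norvegicus), read by radioligand binding (a higher number here means a weaker inhibitor, a lower number a stronger inhibitor), the lowest number among the three compounds measured in this assay. Compound 2 `COc1cc(C(=O)N2CCCC(N(C)C)c3sccc32)ccc1NC(=O)c1ccccc1-c1ccccc1` gives 10 nM in this assay, a higher number that lies beyond the usual scatter from compound 1. Compound 3 `CN(C)CCN1CCCN(C(=O)c2ccc(NC(=O)c3ccccc3-c3ccccc3)cc2)c2ccsc21` gives 20 nM in this assay, the highest of the three and also beyond the scatter from compound 1. Within the data shown here, neither compound 2 nor compound 3 differs from compound 1 in a single place, so no step between measured compounds is available to calibrate the change now considered.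

Compound 4 `CN1CCCN(C(=O)CCCOc2cc(C(=O)N3CCCCc4sccc43)ccc2NC(=O)c2ccccc2-c2ccccc2)CC1` differs from compound 1 by 4-methyl-1,4-diazepan-1-yl in place of 4-methylpiperazin-1-yl on a carbonyl carbon. The change sits on a carbonyl carbon whose other neighbour is a saturated chain carbon, and it adds a single heavy atom to the ring while keeping the count of donors and acceptors and the absence of charge unchanged. Among the measured compounds shown here, no measured pair shows what such a ring enlargement does in this assay, so the expectation rests on the value of compound 1, 1 nM, alone. The step expected from compound 1 to compound 4 is a 1.5-fold higher number from compound 1 to compound 4 (0.18 log units; within the scatter), that is, none beyond the scatter. Compound 4 is accordingly estimated to give 1.5 nM in this assay, with a range from 0.5 nM to 5 nM.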

Compound 4, half-maximal inhibitory concentration: 3 nM
For compound 4 the middle estimate is 2.0-fold (0.30 log units) below the measured one; measured number inside the range.
By their numbers in this assay, from the lowest: compound 1; then compound 4; then compounds 2 and 3 (each within the scatter of the next).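

Among these compounds, the ring enlargement gives the first measured step at this position in this assay: 4-methyl-1,4-diazepan-1-yl in place of 4-methylpiperazin-1-yl on a carbonyl carbon brings a 3.0-fold higher number from compound 1 to compound 4 (0.48 log units; beyond the scatter) and so, though modest, it lies beyond the usual scatter. At this place, whose other neighbour is a saturated chain carbon, the change from a six-membered to a seven-membered non-aromatic ring therefore registers in the read-out, even with one added heavy atom and unchanged counts of hydrogen-bond donors and acceptors, and compound 4 still gives 3 nM in the low nanomolar range. No measurement at hand accounts for the size or direction of this step.

The compounds shown leave open how the number responds when the ring on this carbonyl carbon gives way to a morpholine ring or to an open-chain dimethylamino group. They also leave open whether the methyl on the ring nitrogen matters, which an ethyl group or a plain hydrogen at that nitrogen would test in either the six-membered or the seven-membered ring.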